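The compounds below may be only part of what the source reports. "The series", "measured", "known", "first", "only" and "open" are said of these compounds alone.

Compound 1 `COc1ccc(-c2cn3ccnc3c(-c3ccc4ncn(C5CCCCC5)c4c3)n2)cc1` and compound 2 `COc1ccccc1-c1cn2ccnc2c(-c2ccc3ncn(C4CCCCC4)c3c2)n1` share one core and differ only in that compound 2 carries 2-methoxyphenyl in place of 4-methoxyphenyl on an aromatic carbon. In a functional assay on HCT-116 cells (Homo sapiens) for inhibition, read by sulforhodamine B assay, with a stated time of 48 h, tested at 10 uM (on this read-out higher numbers stand for more inhibition at the one concentration tested (going by the name of the read-out) and lower numbers for less inhibition), compound 1 gives 91.3%, whereas compound 2 gives 28.3%, the lower of the two numbers. That step, a number 63 percentage points lower from compound 1 to compound 2 (beyond the scatter), shows that the attached ring strongly influences this assay. Compound 3 `c1csc(-c2cn3ccnc3c(-c3ccc4ncn(C5CCCCC5)c4c3)n2)c1` carries thiophen-2-yl in place of 2-methoxyphenyl on an aromatic carbon. Among the compounds with values here, no measured step covers this exchange; the one known step only shows that changes to this ring can be large. For compound 3 a rise is expected, a number 26.7 percentage points higher from compound 2 to compound 3 (beyond the scatter), to an estimated 55%, ranging from 20% to 90%.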

Compound 3, a percentage reported as inhibition, at one concentration (the size of the read-out at that concentration, not a potency): 21.1%
Compound 3: middle estimate off by 33.9 percentage points, on the high side; the range from low to high includes it.
By their numbers in this assay, from the lowest: compounds 3 and 2 (each within the scatter of the next); then compound 1.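

In this assay, thiophen-2-yl and 2-methoxyphenyl cannot be told apart at this position: the exchange gives a number 7.2 percentage points lower from compound 2 to compound 3 (within the scatter). Set against 4-methoxyphenyl, the same thiophen-2-yl gives a number 70.2 percentage points lower from compound 1 to compound 3 (beyond the scatter), so among these three groups only 4-methoxyphenyl goes with a high number, and an aromatic ring at this position is not enough on its own to give one. Nothing at hand explains this difference. The compounds shown leave open whether plain phenyl, 4-hydroxyphenyl or 4-aminophenyl would match compound 1.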